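Cell toxicity across four related compounds

This account rests on a few compounds, and the source may have more. Where it says the series, first, only, none or still open, it means among the compounds named here.

The account compares three measured compounds and one still unmeasured in an ADME assay on MT4 cells (Homo sapiens) for cytotoxicity, read by MTT assay, with a stated time of 4 days; on this read-out lower numbers stand for higher toxicity in this test and higher numbers for lower toxicity in this test. Compound 1 `O=c1cc(Cc2c(F)cccc2F)nc(N2CCCCCC2)[nH]1` is the reference. In this assay compound 1 gives > 78000 nM, which is a limit of the assay rather than a number. Compound 2 `CN1CCN(c2nc(Cc3c(F)cccc3F)cc(=O)[nH]2)CC1` differs from compound 1 by 4-methylpiperazin-1-yl in place of azepan-1-yl on an aromatic carbon. In this assay compound 2 gives > 78000 nM, again a limit. Compound 3 `Cc1c(Cc2c(F)cccc2F)nc(N2CCCCCC2)[nH]c1=O` has a different core, differing from compound 1 by methyl in place of hydrogen on an aromatic carbon. In this assay compound 3 gives > 75000 nM, also a limit. The steps a step that the two limits leave unreadable from compound 1 to compound 2 and a step that the two limits leave unreadable from compound 1 to compound 3 cannot be sized because the limit of > 78000 nM in this assay, at which 2 of the 3 values shown sit, and the limit of > 75000 nM in this assay, at which 1 of the 3 values shown sits, cap all three values. Compound 4 `Cc1c(Cc2c(F)cccc2F)nc(N2CCN(C)CC2)[nH]c1=O` arises from compound 3 by 4-methylpiperazin-1-yl in place of azepan-1-yl on an aromatic carbon, the same kind of change as that from compound 1 to compound 2, though here the place is also para to a methyl group. Compound 4 is expected to show a step that the limit leaves unreadable from compound 3 to compound 4, an expectation resting on the unreadable step that the two limits leave unreadable from compound 1 to compound 2. Compound 4 is therefore estimated at 78000 nM.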

Compound 4, half-maximal cytotoxic concentration: > 75000 nM
Compound 4: only a limit was reported; the forecaster's own chance of this, stated with the estimate: 85%; the middle value lies beyond the limit too.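

Compound 4 gives > 75000 nM, which is a limit and not a number. The steps from compound 2 and from compound 3 to compound 4 cannot be read. The compounds shown leave open at what concentration any of the four becomes toxic, and whether either change alters it.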